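Chloro in Place of Acetyl on the Phenyl Ring

The compounds below may be only part of what the source reports. "The series", "measured", "known", "first", "only" and "open" are said of these compounds alone.

Compound 1 `c1ccc(-c2cn3ccnc3c(-c3ccc4ncn(C5CCCCC5)c4c3)n2)cc1`: 59.8%
Compound 2 `Fc1ccc(-c2cn3ccnc3c(-c3ccc4ncn(C5CCCCC5)c4c3)n2)cc1`: 20.4%
Compound 3 `CC(=O)c1ccc(-c2cn3ccnc3c(-c3ccc4ncn(C5CCCCC5)c4c3)n2)cc1`: 23.6%

Three compounds share one core and differ only in the group on the six-membered aromatic ring of carbon only. In a functional assay on SR cells (Homo sapiens) for inhibition, read by sulforhodamine B assay, with a stated time of 48 h, tested at 10 uM (on this read-out lower numbers stand for less inhibition and higher numbers for more inhibition at the one concentration tested (going by the name of the read-out)), compound 1 gives 59.8%, compound 2 gives 20.4% and compound 3 gives 23.6%. Compound 3 thus stands second highest of the three: close to compound 2 and well below compound 1. The two steps from the unsubstituted ring are both large, a number 39.4 percentage points lower from compound 1 to compound 2 (beyond the scatter) and a number 36.2 percentage points lower from compound 1 to compound 3 (beyond the scatter), whereas the step between the two substituted rings, a number 3.2 percentage points higher from compound 2 to compound 3 (within the scatter), lies within the scatter.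

Compound 4 `Clc1ccc(-c2cn3ccnc3c(-c3ccc4ncn(C5CCCCC5)c4c3)n2)cc1` carries a chloro at that place: chloro in place of acetyl on an aromatic carbon. The step that bears most directly on it is a number 3.2 percentage points higher from compound 2 to compound 3 (within the scatter), which showed that exchanging one group for another on this aromatic carbon, para to a large group, left the read-out unchanged, while both substituted compounds sat far below compound 1. Compound 4 is therefore expected to behave like compound 2 and compound 3, with an estimated step of a number 1.4 percentage points higher from compound 3 to compound 4 (within the scatter) in this assay. The estimate for compound 4 is 25%, within a range of 10% to 45%.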

Compound 4, a percentage reported as inhibition, at one concentration (the size of the read-out at that concentration, not a potency): 18.5%
Compound 4: middle estimate off by 6.5 percentage points, on the high side, and the stated range covers the measured number.
By their numbers in this assay, from the lowest: compounds 4, 2 and 3 (each within the scatter of the next); then compound 1.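

In this assay, chloro now joins fluoro and acetyl at this place, on an aromatic carbon para to a large group: the result is a number 5.1 percentage points lower from compound 3 to compound 4 (within the scatter) and a number 1.9 percentage points lower from compound 2 to compound 4 (within the scatter), so the three groups cannot be told apart here. The gap to the unsubstituted ring also holds for this third group, at a number 41.3 percentage points lower from compound 1 to compound 4 (beyond the scatter), and among these four compounds only compound 1, with hydrogen at this place, stands apart. Nothing among the data shown explains why these groups give the lower number.

From the compounds shown here alone, it remains open whether an amine or a carboxylic acid at this place would stay with compounds 2, 3 and 4 or come closer to compound 1. Going by these compounds, it is also open whether the same gap would appear with a methyl group there.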